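A few compounds are considered here, and "the series" means these few. Any claim that something is new, unique, unknown or untested is made for them only; others in the source may bear on it.

Measured so far in a functional assay on MCF7 cells (Homo sapiens) for inhibition, read by MTT assay, with a stated time of 72 h; a lower number here means a stronger inhibitor, a higher number a weaker inhibitor:
- compound 1 `CN(C(=O)NC(=O)c1ccc(Cl)cc1Cl)c1nc(C(F)(F)F)c(C(=O)N/N=C/c2ccc(C(F)(F)F)cc2)s1`: compound 1 gives 8.42 ug/mL.
- compound 2 `CNc1nc(C)c(C(=O)N/N=C/c2cccc(C(F)(F)F)c2)s1`: compound 2 gives only a limit of the assay, > 100 ug/mL.
- compound 3 `CNc1nc(C(F)(F)F)c(C(=O)N/N=C/c2cccc(C(F)(F)F)c2)s1`: compound 3 likewise gives only a limit, > 100 ug/mL.

Among the measured compounds shown here, compound 1 is the only compound with a number in this assay; the other two values sit at the limit of > 100 ug/mL in this assay, at which 2 of the 3 values shown sit. For the measured compounds named here, the one change made twice in this set is methyl in place of trifluoromethyl on an aromatic carbon, which gives a step that the two limits leave unreadable from compound 3 to compound 2. The difference between the core of compound 1 and that of compound 3 is not broken down here.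

Compound 4 `Cc1nc(N(C)C(=O)NC(=O)c2ccc(Cl)cc2Cl)sc1C(=O)N/N=C/c1ccc(C(F)(F)F)cc1` is not yet measured. From compound 1 it differs by methyl in place of trifluoromethyl on an aromatic carbon, the same kind of change as from compound 3 to compound 2, but around the place the ring atom two ring bonds away bears a large group rather than a methylamino group (2 heavy atoms). Since the measured step is unreadable, compound 4 is expected to stay close to compound 1, with a 1.4-fold higher number from compound 1 to compound 4 (0.15 log units; within the scatter) as the estimated step. For compound 4 the estimate in this assay is 12 ug/mL, roughly between 4 ug/mL and 40 ug/mL.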

Compound 4, half-maximal inhibitory concentration: 24.5 ug/mL
Compound 4: the middle estimate sits 2.0-fold (0.31 log units) below what was measured, within the range that was stated.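

Where the ring atom two ring bonds away bears a large group, methyl in place of trifluoromethyl on an aromatic carbon gives a 2.9-fold higher number from compound 1 to compound 4 (0.46 log units; beyond the scatter) in this assay. The same change from compound 3 to compound 2 cannot be read, so these compounds do not show whether the step carries over from one core to another: the limit of > 100 ug/mL in this assay, at which 2 of the 4 values shown sit.

The readable step therefore describes a single pair on a single core and establishes no general effect of this change across the series. Still open, on these data alone, is how this assay responds to other groups on this aromatic carbon, such as an ethyl group, a nitrile or a carboxylic acid. Among the compounds shown here, the one readable pair also leaves open whether the step would hold with the trifluoromethyl on the benzylidene ring kept as it is on another core.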